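This account rests on a few compounds, and the source may have more. Where it says the series, first, only, none or still open, it means among the compounds named here.

Measured compounds:
compound 1, `CC1(c2ccccc2)CC(=O)N(CC(=O)N2CCN(c3ccccc3F)CC2)C1=O`, 100 mg/kg
compound 2, `CC1(c2ccccc2)CC(=O)N(CC(=O)N2CCN(c3ccc(F)cc3)CC2)C1=O`, "not active" (no number reported)

In a functional assay on the whole organism (strain CD-1) with Mus musculus as the target, with a stated time of 0.5 h (a higher number here means that more compound is needed for the effect, a lower number that less compound is needed), compound 1 gives 100 mg/kg. Among the measured compounds shown here, this is the only number in the set: compound 2, in which the fluorine sits at another position of the phenyl ring on the piperazine nitrogen, is reported in this assay as "not active" (no number reported) without a number, so no step between measured compounds can be stated. Compound 3, `CC1(c2ccccc2)CC(=O)N(CC(=O)N2CCN(c3ncccn3)CC2)C1=O`, is not yet measured. It differs from compound 1 as follows: pyrimidin-2-yl in place of 2-fluorophenyl on an amine nitrogen in a ring. The entering pyrimidin-2-yl carries hydrogen-bond acceptors where the 2-fluorophenyl carries none. For the measured compounds named here, with only one number available and the nearest measured neighbour returning no number, the expected step from compound 1 to compound 3 in this assay, no change at the digits printed from compound 1 to compound 3 (within the scatter), is set at none beyond the scatter. Compound 3 is therefore expected to show about 100 mg/kg in this assay, within the range 30 mg/kg to 300 mg/kg.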

Compound 3, minimum effective dose: "not active" (no number reported)
The entry for compound 3 holds no number; there is nothing to compare the estimate with.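

In this assay, among the compounds shown here, compound 3, like compound 2, is reported without a number, so no step from compound 1 can be read. The compounds shown leave open how far either entry lies from compound 1. No measured evidence here bears on this result.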